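A few compounds are considered here, and "the series" means these few. Any claim that something is new, unique, unknown or untested is made for them only; others in the source may bear on it.

In a functional assay on brain (Rattus norvegicus, strain Wistar) for inhibition (on this read-out lower numbers stand for stronger inhibition and higher numbers for weaker inhibition), compound 1 `CCCCCOc1ccc(-c2c(C)[nH]c(=O)n2C)cc1` gives 4500 nM. Compound 2 `CCCCCCOc1ccc(-c2c(C)[nH]c(=O)n2C)cc1`, which has the same shared core with a hexyloxy chain, gives 7300 nM. These two numbers lie within the scatter of each other, so compound 2 cannot be ranked against compound 1 and simply stands level with it.

Compound 3 `CCCCCCCc1ccc(-c2c(C)[nH]c(=O)n2C)cc1` differs from compound 2 in the chain: heptyl in place of hexyloxy on an aromatic carbon. In words, this is heptyl in place of hexyloxy on an aromatic carbon, so the oxygen of the chain is gone.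

For the measured compounds named here, only one measured step bears on this change: a 1.6-fold higher number from compound 1 to compound 2 (0.21 log units; within the scatter). In that step the chain gains a methyl, while the oxygen stays in place. Going by the values given here, it suggests that small changes to this chain may matter little in this assay, but no measured pair shows what losing the oxygen does. Neither direction is therefore favoured, and the range must stay wide.

The expected change is a 1.0-fold lower number from compound 2 to compound 3 (0.02 log units; within the scatter), which would be no real shift beyond the scatter. For compound 3, the estimated value is 7000 nM, with an expected range from 2500 nM to 20000 nM.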

Compound 3, half-maximal inhibitory concentration: 8400 nM
Compound 3: middle estimate off by 1.2-fold (0.08 log units), on the low side; low and high end bracket the measured number.
By their numbers in this assay, from the lowest: compounds 1, 2 and 3 (each within the scatter of the next).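

Measured in this assay the swap of hexyloxy for heptyl gives a 1.2-fold higher number from compound 2 to compound 3 (0.06 log units; within the scatter) and the swap of pentyloxy for heptyl gives a 1.9-fold higher number from compound 1 to compound 3 (0.27 log units; within the scatter) as the wider comparison. Compound 1 and compound 2 both carry an oxygen in the chain, so they could not show what happens without it; compound 3 shows that, among these three compounds, a chain of carbon only on this aromatic carbon stands level with the chains that hold an oxygen. Nothing measured here explains this result.

Going by these compounds, the three chains are all similar in size and lie within the scatter of their neighbours, so it remains open whether a much shorter chain such as methoxy or a longer chain such as decyl would read differently. On these data alone, it is also open what a chain ending in an amine or a carboxylic acid would do in this assay, and whether any change at this place can move the inhibition beyond the scatter.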